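Swapping a furan for a methoxyphenyl on a dienone

The source may report more compounds than this note shows. Statements on the series, on what has been measured and on what is new or still open speak of the compounds shown alone.

All four compounds share a core: a dienone linked through a triazole to a coumarin. Compound 1 `COc1ccccc1/C=C/C(=O)/C=C/c1ccc(OCc2cn(CCCOc3cc(=O)oc4ccccc34)nn2)c(OC)c1` and compound 3 `COc1cc(/C=C/C(=O)/C=C/c2ccco2)ccc1OCc1cn(CCCOc2cc(=O)oc3ccccc23)nn1` carry, at one end of the dienone, a 2-methoxyphenyl and a furan-2-yl ring; compound 2 `COc1cc(/C=C/C(=O)/C=C/c2cc(OC)c(OC)c(OC)c2)ccc1OCc1cn(CCOc2cc(=O)oc3ccccc23)nn1` carries a 3,4,5-trimethoxyphenyl ring. In a functional assay on PC-3 cells (Homo sapiens) for inhibition, read by sulforhodamine B assay, with a stated time of 48 h, tested at 50 uM (a higher number here means more inhibition of growth at the concentration tested, a lower number less inhibition of growth), compound 2 gives 22%, while compound 1 gives "not active" (no number reported) and compound 3 gives "not active" (no number reported). Compound 3 thus stands among the two members of the set for which no number, only the statement of inactivity, is recorded.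

Compound 4 `COc1ccc(/C=C/C(=O)/C=C/c2ccc(OCc3cn(CCCOc4cc(=O)oc5ccccc45)nn3)c(OC)c2)cc1` is the next step from compound 3: 4-methoxyphenyl in place of furan-2-yl on a double-bonded chain carbon bound to a double-bonded chain carbon. The closest measured relative is compound 2, whose single methoxy-bearing aryl cousins show little. Going by the values given here, with no measured step of this kind available, the move from compound 3 to compound 4 is expected to bring at most a small rise in growth inhibition, likely not beyond the usual scatter, and with a fair chance that inactivity is again reported. Compound 4 is expected to give about 12%, within 0% to 30%.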

Compound 4, percent growth inhibition at one concentration: "not active" (no number reported)
No number was reported for compound 4; no gap can be computed for the estimate.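

Compound 3 and compound 4 are both reported as inactive without a number, so no step can be read from furan-2-yl to 4-methoxyphenyl. Nothing measured here explains this result. In this assay, as far as these compounds go, it stays open whether this swap changes growth inhibition at all.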